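The compounds below may be only part of what the source reports. "The series", "measured", "known", "first", "only" and "open" are said of these compounds alone.

Within the data shown here, compound 1 `O=C(/C=C\N(O)Cc1ccccc1)c1ccc(Cl)c(Cl)c1` is one of two compounds measured in an assay on RBL-1 cells for inhibition of Polyunsaturated fatty acid 5-lipoxygenase (Rattus norvegicus); a higher number here means a weaker inhibitor, a lower number a stronger inhibitor. In this assay compound 1 gives 610 nM, the higher of the two numbers, while compound 2 `O=C(/C=C\N(O)C1CCCCC1)c1ccc(F)cc1` gives 270 nM, a gap beyond the usual scatter. Compound 3 `O=C(/C=C\N(O)Cc1ccccc1)c1ccc(Cl)cc1` differs from compound 1 in one place: hydrogen in place of chloro on an aromatic carbon. Among the measured compounds shown here, no pair of measured compounds shows what this change does, so the expectation rests on compound 1 alone. A modest weakening is expected, the estimated step being a 1.5-fold higher number from compound 1 to compound 3 (0.17 log units; within the scatter). Compound 3 is therefore expected to give about 900 nM, with a range from 400 nM to 2000 nM.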

Compound 3, half-maximal inhibitory concentration: 1500 nM
The estimate for compound 3 lay 1.7-fold (0.22 log units) below the measured number, within the range that was stated.
By their numbers in this assay, from the lowest: compound 2; then compound 1; then compound 3.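

Putting hydrogen in place of this chloro group, ortho to a chloro group, gives a 2.5-fold higher number from compound 1 to compound 3 (0.39 log units; beyond the scatter) in this assay, so this one atom on the aromatic ring makes a real difference to inhibition. The finding rests on a single pair of compounds and so applies only to the core of compound 1. Going by these compounds, whether a bromo, methyl or methoxy group at this place would match chloro remains open. No measurement shown explains why losing this chloro group weakens inhibition.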